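The source may report more compounds than this note shows. Statements on the series, on what has been measured and on what is new or still open speak of the compounds shown alone.

Measured in a functional assay on Raji cells (Homo sapiens) for antiproliferative activity, read by MTT assay, with a stated time of 48 h; a lower number here means a stronger inhibitor, a higher number a weaker inhibitor:
Compound 1 `N#Cc1nc2c(-c3nc4ccccc4[nH]3)c(N)n(CCN3CCCC3)c2nc1C#N`: > 50000 nM, a limit of the assay.
Compound 2 `CN(C)CCCn1c(N)c(-c2nc3ccccc3[nH]2)c2nc(C#N)c(C#N)nc21`: 1230 nM.
Compound 3 `N#Cc1nc2c(-c3nc4ccccc4[nH]3)c(N)n(CCCN3CCCCC3)c2nc1C#N`: 3380 nM.

In this assay, compound 3 carries the higher of the two actual numbers, and its nearest neighbour is compound 2, with a 2.7-fold higher number from compound 2 to compound 3 (0.44 log units; beyond the scatter). Compound 4 `CCN(CC)CCCCn1c(N)c(-c2nc3ccccc3[nH]2)c2nc(C#N)c(C#N)nc21` differs from compound 3 as follows: (diethylamino)methyl in place of piperidin-1-yl on a saturated chain carbon, three bonds along the chain from an aromatic nitrogen. This puts (diethylamino)methyl in place of piperidin-1-yl, so 3-(piperidin-1-yl)propyl becomes 4-(diethylamino)butyl. Among the measured compounds shown here, the closest precedent is the modest step at this same place, where compound 2, with its open-chain amine, gives the lower number (a 2.7-fold higher number from compound 2 to compound 3 (0.44 log units; beyond the scatter)). The large steps of an at least 40-fold lower number from compound 1 to compound 2 (1.60 log units; beyond the scatter) and an at least 14-fold lower number from compound 1 to compound 3 (1.17 log units; beyond the scatter) start from a limit and bear only loosely. A modest drop is therefore expected, estimated as a 1.8-fold lower number from compound 3 to compound 4 (0.25 log units; within the scatter). For compound 4 the expected value is 1900 nM, with an estimated range of 600 nM to 6500 nM.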

Compound 4, half-maximal inhibitory concentration: 2640 nM
Beside the measured number, compound 4's estimate is 1.4-fold (0.14 log units) below it; measured number inside the range.
By their numbers in this assay, from the lowest: compound 2; then compounds 4 and 3 (each within the scatter of the next). At a limit, above all of these: compound 1.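

In this assay, exchanging 3-(piperidin-1-yl)propyl for the open 4-(diethylamino)butyl keeps the two compounds within the scatter, a 1.3-fold lower number from compound 3 to compound 4 (0.11 log units; within the scatter), so an open-chain amine alone does not secure a lower number. Compound 2 still stands apart, a 2.1-fold higher number from compound 2 to compound 4 (0.33 log units; beyond the scatter), which shows that compound 4 does not share its standing despite also carrying an open-chain amine. Compound 1 remains a limit, so an at least 18-fold lower number from compound 1 to compound 4 (1.27 log units; beyond the scatter) gives only a bound: the limit of > 50000 nM in this assay, at which 1 of the 4 values shown sits.

The compounds shown leave open whether the gap to compound 2 follows the chain or the amine, since both change together. A 3-(diethylamino)propyl chain would separate the two.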